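The source may hold more compounds than are shown below. What is called first, only, known or untested is meant among the compounds shown, and "the series" means these compounds.

Measured compounds in a functional assay on HCT-116 cells (Homo sapiens) for cytotoxicity, read by MTT assay, with a stated time of 48 h; a higher number here means a weaker inhibitor, a lower number a stronger inhibitor:
- compound 1 `O=C(/C=C\Nc1ccc(F)cc1)c1nc(-c2ccc(F)cc2)n2ccccc12` gives > 30000 nM, a limit of the assay.
- compound 2 `COc1ccc(N/C=C\C(=O)c2nc(-c3ccc(C(F)(F)F)cc3)n3ccccc23)cc1OC` gives > 30000 nM, again a limit of the assay.
- compound 3 `O=C(/C=C\Nc1ccc(F)cc1)c1nc(-c2ccc(C(F)(F)F)cc2)n2ccccc12` gives > 30000 nM, also a limit of the assay.

Compound 2 therefore stands at the limit, where every value shown in this assay sits (the limit of > 30000 nM in this assay, at which 3 of the 3 values shown sit). No number places it above or below its neighbours.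

Compound 4 `COc1ccc(N/C=C\C(=O)c2nc(-c3ccc(C(F)(F)F)cc3)n3ccccc23)cc1` is the unmeasured compound. It differs from compound 2 by hydrogen in place of methoxy on an aromatic carbon.

Within the data shown here, two measured steps touch this series, but both run between limits: a step that the two limits leave unreadable from compound 1 to compound 3 and a step that the two limits leave unreadable from compound 2 to compound 3, so neither has a readable size, and neither involves the methoxy group that is removed here. Among the measured compounds shown here, the data give no measured step for hydrogen in place of methoxy on an aromatic carbon. With every value in this assay at the limit (the limit of > 30000 nM in this assay, at which 3 of the 3 values shown sit), compound 4 is expected to be reported at that limit as well, and the expected step of a number no higher from compound 2 to compound 4 (the limit leaves the size open) is none beyond the scatter.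

The estimate for compound 4 in this assay is 30000 nM, within a range from 10000 nM to 100000 nM, most likely as a limit rather than a number.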

Compound 4, half-maximal inhibitory concentration: 7720 nM
The estimate for compound 4 lay 3.9-fold (0.59 log units) above the measured number; measured number below the stated range.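

Compound 4 gives this series its first readable steps in this assay, and they fall on the aromatic ring carried by the amine nitrogen. Going from 3,4-dimethoxyphenyl to 4-methoxyphenyl, with hydrogen entering ortho to the remaining methoxy group, gives an at least 3.8-fold lower number from compound 2 to compound 4 (0.58 log units; beyond the scatter), while methoxy in place of fluoro on an aromatic carbon gives an at least 3.8-fold lower number from compound 3 to compound 4 (0.58 log units; beyond the scatter). Among the compounds shown, only the 4-methoxyphenyl group gives a number rather than a limit, so this position can respond to a small change, but both sizes are only minimums and the earlier steps cannot be read: the limit of > 30000 nM in this assay, at which 3 of the 4 values shown sit.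

As far as these compounds go, how far compound 2 and compound 3 truly lie from compound 4 stays open, as does whether the 4-methoxyphenyl group would give a number with the 4-fluorophenyl group of compound 1 on the other side of the shared core. Also open, from the compounds shown here alone, is how a hydroxy group, an ethoxy group or a dimethylamino group would compare in place of the remaining methoxy group, and how a plain phenyl group on the amine nitrogen would compare with the 4-methoxyphenyl group.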